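Methyl Added to the Phenyl Ring: Expected Cytotoxicity

A few compounds are considered here, and "the series" means these few. Any claim that something is new, unique, unknown or untested is made for them only; others in the source may bear on it.

In a functional assay on MDA-MB-231 cells (Homo sapiens) for cytotoxicity, read by MTT assay, with a stated time of 48 h (on this read-out lower numbers stand for stronger inhibition and higher numbers for weaker inhibition), the measured compounds gave:
Compound 1, `Nc1nc(-c2ccccc2)cn1/N=C/c1cc2ccccc2nc1Cl`: 49000 nM
Compound 2, `Cc1ccc(-c2cn(/N=C/c3cc4ccccc4nc3Cl)c(N)n2)cc1`: only a limit of the assay, > 50000 nM
Compound 3, `Cc1ccc2nc(Cl)c(/C=N/n3cc(-c4ccccc4)nc3N)cc2c1`: 48100 nM

Compound 3 shows the lowest of the two numbers, but the step of a 1.0-fold lower number from compound 1 to compound 3 (0.01 log units; within the scatter) is within the scatter, so compound 1 and compound 3 cannot be told apart. Compound 4, `Cc1ccc(-c2cn(/N=C/c3cc4cc(C)ccc4nc3Cl)c(N)n2)cc1`, differs from compound 3 by methyl in place of hydrogen on an aromatic carbon. The same change on compound 1 gave an at least 1.0-fold higher number from compound 1 to compound 2 (0.00 log units; that floor lies within the scatter), ending at the assay limit (the limit of > 50000 nM in this assay, at which 1 of the 3 values shown sits). No gain is therefore expected in this assay ; the step is estimated as a 1.2-fold higher number from compound 3 to compound 4 (0.10 log units; within the scatter), with compound 4 likely reaching the limit again. Compound 4 is estimated at 60000 nM, ranging from 30000 nM to 130000 nM.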

Compound 4, half-maximal inhibitory concentration: 22300 nM
Beside the measured number, compound 4's estimate is 2.7-fold (0.43 log units) above it; measured number below the stated range.
By their numbers in this assay, from the lowest: compound 4; then compounds 3 and 1 (each within the scatter of the next). At a limit, above all of these: compound 2.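

Phenyl to 4-methylphenyl gave no readable gain on the core of compound 1, but in this assay it gives a real drop on the core that already carries a methyl: a 2.2-fold lower number from compound 3 to compound 4 (0.33 log units; beyond the scatter). The other methyl also counts once the 4-methylphenyl is present, with an at least 2.2-fold lower number from compound 2 to compound 4 (0.35 log units; beyond the scatter), although that step starts from a limit of the assay.

From the compounds shown here alone, whether the change truly acts differently on the two cores stays unsettled: the same change on two cores in this assay, an at least 1.0-fold higher number (0.00 log units; that floor lies within the scatter) from compound 1 to compound 2 and a 2.2-fold lower number (0.33 log units; beyond the scatter) from compound 3 to compound 4; the limit leaves it open whether they differ Whether a methoxy group or a fluorine in place of the 4-methyl would lower the number further also stays open.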